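The source may report more compounds than this note shows. Statements on the series, on what has been measured and on what is new or still open speak of the compounds shown alone.

Compound 1, `CC(C)=CCC/C(C)=C/COc1cc(=O)n(CCCO)c2c1CC(CC=C(C)C)C(C)(C)C2`: 10.6%
Compound 2, `CC(C)=CCC1Cc2c(OC(=O)Nc3ccc(F)cc3)cc(=O)n(CCCO)c2CC1(C)C`: 71.2%
Compound 3, `CC(C)=CCC1Cc2c(OC(=O)Nc3cccc(F)c3)cc(=O)n(CCCO)c2CC1(C)C`: 66.1%

In a functional assay on PANC-1 cells (Homo sapiens) for inhibition, read by MTT assay, with a stated time of 24 h, tested at 10 uM (on this read-out lower numbers stand for less inhibition and higher numbers for more inhibition at the one concentration tested (going by the name of the read-out)), compound 3 gives 66.1%, the second highest of the three numbers. Its nearest neighbour is compound 2, and the step of a number 5.1 percentage points lower from compound 2 to compound 3 (within the scatter) lies within the scatter, whereas the step of a number 55.5 percentage points higher from compound 1 to compound 3 (beyond the scatter) lies well beyond it. Compound 4, `CC(C)=CCC1Cc2c(OC(=O)Nc3ccccc3F)cc(=O)n(CCCO)c2CC1(C)C`, has not yet been measured. It differs from compound 3 by 2-fluorophenyl in place of 3-fluorophenyl on an amide-type nitrogen, the same atoms being joined differently. Going by the values given here, the only measured step that bears on this kind of change is a number 5.1 percentage points lower from compound 2 to compound 3 (within the scatter), which is within the scatter; the two large steps, a number 60.6 percentage points higher from compound 1 to compound 2 (beyond the scatter) and a number 55.5 percentage points higher from compound 1 to compound 3 (beyond the scatter), concern a different exchange and do not apply here. Since compound 2 and compound 3 sit close together, the step of a number 0.1 percentage points lower from compound 3 to compound 4 (within the scatter) is expected to stay within the scatter, with no clear direction. Compound 4 is therefore estimated to give about 66%, within a range from 50% to 80%.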

Compound 4, a percentage reported as inhibition, at one concentration (the size of the read-out at that concentration, not a potency): 52.3%
Compound 4: the middle estimate sits 13.7 percentage points above what was measured; low and high end bracket the measured number.
By their numbers in this assay, from the lowest: compound 1; then compound 4; then compounds 3 and 2 (each within the scatter of the next).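

In this assay, the place of the fluorine on the phenyl ring now makes a difference. Compound 2 and compound 3 had stayed within the scatter of each other, but the results show a number 13.8 percentage points lower from compound 3 to compound 4 (beyond the scatter) and a number 18.9 percentage points lower from compound 2 to compound 4 (beyond the scatter), so 2-fluorophenyl on the amide-type nitrogen stands apart from the other two fluorophenyl groups, though the exchange on the oxygen remains large with 2-fluorophenyl, at a number 41.7 percentage points higher from compound 1 to compound 4 (beyond the scatter). No measurement at hand explains why 2-fluorophenyl differs from 3-fluorophenyl and 4-fluorophenyl.

The compounds shown leave open how plain phenyl compares with these three fluorophenyl groups, and whether 2-chlorophenyl or 2-methoxyphenyl would fall with 2-fluorophenyl or with the other two. They also leave open whether this order holds at other concentrations or in other cell lines.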